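Methoxy Removal on Pyridylmethyl Imines in the Electroshock Model

A few compounds are considered here, and "the series" means these few. Any claim that something is new, unique, unknown or untested is made for them only; others in the source may bear on it.

Measured compounds:
- compound 1 `C(=N/Cc1cccnc1)\c1ccccc1`: 100 mg/kg
- compound 2 `COc1cc(/C=N/Cc2cccnc2)cc(OC)c1OC`: 100 mg/kg
- compound 3 `COc1ccccc1/C=N/Cc1cccnc1`: 30 mg/kg

In a functional assay on the whole organism (strain Swiss albino) with Mus musculus as the target, in the maximal electroshock model, with a stated time of 0.5 h (on this read-out higher numbers stand for an effect only at larger amounts of compound and lower numbers for an effect already at smaller amounts), compound 3 gives 30 mg/kg, while compound 1 gives 100 mg/kg and compound 2 gives 100 mg/kg. Compound 2 stands level with compound 1 at the digits printed, and the two together carry the highest numbers of the three. The change from compound 3 to compound 1 is hydrogen in place of methoxy on an aromatic carbon, and it made a 3.3-fold higher number from compound 3 to compound 1 (0.52 log units; beyond the scatter). How the cores of compound 2 and compound 3 differ is not broken down here; their values show the gap already named.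

Compound 4 `COc1ccc(/C=N/Cc2cccnc2)cc1OC` is not yet measured in this assay. Its change from compound 2 is hydrogen in place of methoxy on an aromatic carbon. For the measured compounds named here, this is the same kind of change as the one from compound 3 to compound 1, but not the same: there the methoxy sat ortho to a group of 9 heavy atoms, whereas here it sits ortho to a methoxy group, meta to a group of 9 heavy atoms and meta to a methoxy group. Because compound 3 gives 30 mg/kg and the step of a 3.3-fold higher number from compound 3 to compound 1 (0.52 log units; beyond the scatter) went toward a higher number on losing a methoxy, compound 4 is expected to show a step of about a 1.3-fold higher number from compound 2 to compound 4 (0.11 log units; within the scatter), with the different surroundings leaving wide room. Compound 4 is estimated at 130 mg/kg, between 50 mg/kg and 300 mg/kg.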

Compound 4, minimum effective dose: 300 mg/kg
For compound 4 the middle estimate is 2.3-fold (0.36 log units) below the measured one, and the stated range covers the measured number.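

In this assay, hydrogen in place of methoxy on an aromatic carbon gave a 3.0-fold higher number from compound 2 to compound 4 (0.48 log units; beyond the scatter), so losing this methoxy again raised the minimum effective dose. Set beside the earlier step, the change carried over from one core to the other at much the same size: the same change on two cores in this assay, a 3.3-fold higher number (0.52 log units; beyond the scatter) from compound 3 to compound 1 and a 3.0-fold higher number (0.48 log units; beyond the scatter) from compound 2 to compound 4, 1.1-fold (0.05 log units) apart, within the scatter of two such steps This agreement rests on only two pairs in a single assay, with the methoxy in different surroundings, so it does not show why the number rises, nor that the step would keep its size on other cores in the series.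

The compounds shown leave open what happens when a group other than hydrogen takes the place of the methoxy, such as an amine, a carboxylic acid or a longer chain like ethoxy. They also leave open whether a chlorine atom on the aromatic ring would give a number closer to that of the methoxy compounds or to that of their hydrogen counterparts.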